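The source may report more compounds than this note shows. Statements on the series, on what has been measured and on what is new or still open speak of the compounds shown alone.

Measured so far in a functional assay on L02 cells (Homo sapiens) for inhibition, read by Griess assay, with stated times of 1 h and 24 h; on this read-out higher numbers stand for weaker inhibition and lower numbers for stronger inhibition:
Compound 1 `CCCc1nn(C)c2c(NCc3ccc(F)cc3)nc(/C=C/c3nc(C)c(C)nc3C)nc12` gives > 1000000 nM, which is a limit of the assay rather than a number.
Compound 2 `CCCc1nn(C)c2c(NC3CC3)nc(/C=C/c3cccnc3)nc12` gives 261000 nM.
Compound 3 `CCCc1nn(C)c2c(NCc3ccc(F)cc3)nc(/C=C/c3cccnc3)nc12` gives 940000 nM.

Among the two numbers, compound 3 stands highest, so it is the weaker inhibitor of the pair; the step of a 3.6-fold higher number from compound 2 to compound 3 (0.56 log units; beyond the scatter) separates it from compound 2. Compound 1 sits only at the limit of > 1000000 nM in this assay, at which 1 of the 3 values shown sits.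

Compound 4 `CCCc1nn(C)c2c(NCc3ccc(F)cc3)nc(/C=C/c3ccc[n+]([O-])c3)nc12` differs from compound 3 by a group of 7 heavy atoms (5 carbon, 1 nitrogen, 1 oxygen; one six-membered aromatic ring with 1 hetero atom) in place of a group of 6 heavy atoms (5 carbon, 1 nitrogen; one six-membered aromatic ring with 1 hetero atom), on a double-bonded chain carbon bound to a double-bonded chain carbon. Among the measured compounds shown here, only one measured step touches the same place: an at least 1.0-fold lower number from compound 1 to compound 3 (0.02 log units; that floor lies within the scatter), where the group on the double-bonded chain carbon was exchanged and compound 1 reached only the limit, so the size of that step is unknown beyond its floor. The step of a 3.6-fold higher number from compound 2 to compound 3 (0.56 log units; beyond the scatter) concerns a different place and does not bear on this exchange. For the measured compounds named here, no measured compound carries the entering group, so the direction cannot be read from the data. The expectation is therefore a step of a 1.3-fold higher number from compound 3 to compound 4 (0.11 log units; within the scatter), that is, no change beyond the scatter, with a real chance that the number is again only a limit. Compound 4 is estimated at 1200000 nM, within 400000 nM to 3500000 nM.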

Compound 4, half-maximal inhibitory concentration: < 40000 nM
Compound 4 gave a limit, no number; the forecaster's own chance of this, stated with the estimate: 50%; middle value at least 30-fold (1.47 log units) from the limit.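

Placing the group of 7 heavy atoms, which adds an oxygen to the same six-membered aromatic ring, in place of pyridin-3-yl on a double-bonded chain carbon gives an at least 23-fold lower number from compound 3 to compound 4 (1.37 log units; beyond the scatter) in this assay, so this small exchange brings much stronger inhibition. Replacing 3,5,6-trimethylpyrazin-2-yl at this place with the same entering group gives an at least 25-fold lower number from compound 1 to compound 4 (1.39 log units; beyond the scatter), whereas the earlier exchange here, to pyridin-3-yl, showed only a floor within the scatter. Compound 4 gives a limit rather than a number, so both new steps are floors and their full size stays unknown: the limit of < 40000 nM in this assay, at which 1 of the 4 values shown sits.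

The compounds shown leave open how far past that limit compound 4 lies, and whether the same exchange acts alike with cyclopropyl on the nitrogen, as in compound 2. They also leave open what an amine or a carboxylic acid on this ring would do.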